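A few compounds are considered here, and "the series" means these few. Any claim that something is new, unique, unknown or untested is made for them only; others in the source may bear on it.

Compound 1 `O=C(N/N=C/c1ccc(Cl)cc1)c1cccnc1Nc1cccc(C(F)(F)F)c1` and compound 2 `O=C(N/N=C/c1ccc(O)c(O)c1)c1cccnc1Nc1cccc(C(F)(F)F)c1` share one core and differ only in the ring on the carbon with a double bond to nitrogen. In a functional assay on the whole organism (strain Wistar) for inhibition, with Rattus norvegicus as the target, read by paw edema, with a stated time of 2 h, at a dose of 10 mg/kg by the intraperitoneal route (a lower number here means less inhibition, a higher number more inhibition at the dose given (going by the name of the read-out)), compound 1 gives 52.8% and compound 2 gives 46.9%; the step of a number 5.9 percentage points lower from compound 1 to compound 2 (within the scatter) lies within the scatter, so compound 2 stands level with compound 1 rather than apart from it. Compound 3 `COc1ccc(/C=N/NC(=O)c2cccnc2Nc2cccc(C(F)(F)F)c2)c(OC)c1` alters the same ring: 2,4-dimethoxyphenyl in place of 3,4-dihydroxyphenyl on a carbon with a double bond to nitrogen. Among the compounds with values here, the only measured step, a number 5.9 percentage points lower from compound 1 to compound 2 (within the scatter), offers a loose guide, and it stayed within the scatter. A step of about a number 3.1 percentage points higher from compound 2 to compound 3 (within the scatter) is therefore expected. Compound 3 is estimated at 50%, within 35% to 65%.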

Compound 3, a percentage reported as inhibition, in the whole organism at one dose (the size of the read-out at that dose, not a potency): 44.7%
Estimate against measurement, compound 3: 5.3 percentage points above; the measured number falls inside the stated range.
By their numbers in this assay, from the lowest: compounds 3, 2 and 1 (each within the scatter of the next).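

In this assay, 2,4-dimethoxyphenyl in place of 3,4-dihydroxyphenyl gives a number 2.2 percentage points lower from compound 2 to compound 3 (within the scatter), and 2,4-dimethoxyphenyl in place of 4-chlorophenyl gives a number 8.1 percentage points lower from compound 1 to compound 3 (within the scatter). All three rings on this carbon therefore stand level, and even going from 2 hydrogen-bond donors to 0 on the ring leaves the number within the scatter. No measurement at hand accounts for this.

On these data alone, whether an amine or a carboxylic acid on this ring would move the number beyond the scatter stays open. A single dose also leaves potency unknown.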